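From tert-butyl to cyclohexyl at a measurement limit

The source may hold more compounds than are shown below. What is called first, only, known or untested is meant among the compounds shown, and "the series" means these compounds.

Compound 1 `CCCCOC(=O)c1cnc(Oc2ccc3c(c2)B(O)OC3)cn1`: > 100000 nM
Compound 2 `CC(C)(C)OC(=O)c1cnc(Oc2ccc3c(c2)B(O)OC3)cn1`: > 100000 nM

In an ADME assay on Jurkat cells (Homo sapiens) for cytotoxicity, read by MTT assay, with a stated time of 72 h (a higher number here means a weaker inhibitor, a lower number a stronger inhibitor), compound 2 gives > 100000 nM, which is a limit and not a number. In this assay compound 1 gives > 100000 nM, which is also a limit.

The next compound is compound 3 `O=C(OC1CCCCC1)c1cnc(Oc2ccc3c(c2)B(O)OC3)cn1`, and the change is cyclohexyl in place of tert-butyl on an oxygen next to a carbonyl group. For the measured compounds named here, the one measured step that bears on it is a step that the two limits leave unreadable from compound 1 to compound 2, which also alters the group on that oxygen. It offers no size to carry over. The evidence so far is the limit of > 100000 nM in this assay, at which 2 of the 2 values shown sit. On that basis, no step beyond the scatter is expected in this assay, and no direction can be named. The estimate means a number no higher from compound 2 to compound 3 (the limit leaves the size open), an expected step that stays within the scatter. For compound 3 the expected value is 100000 nM, with an estimated range of 50000 nM to 200000 nM.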

Compound 3, half-maximal inhibitory concentration: 52400 nM
For compound 3 the middle estimate is 1.9-fold (0.28 log units) above the measured one; the range from low to high includes it.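

In this assay, compound 3 is the first compound shown with a readable number, 52400 nM. A change on an oxygen next to a carbonyl group can therefore bring a value down from the measurement limit. Cyclohexyl in place of tert-butyl gives an at least 1.9-fold lower number from compound 2 to compound 3 (0.28 log units; that floor lies within the scatter), and cyclohexyl in place of butyl gives an at least 1.9-fold lower number from compound 1 to compound 3 (0.28 log units; that floor lies within the scatter); these are floors, so the true size of each step stays open. For the compounds shown here, only one compound has left the limit, so this is a single result and not yet a trend: the limit of > 100000 nM in this assay, at which 2 of the 3 values shown sit.

Still open, from the compounds shown here alone, is whether a different ring, such as cyclopentyl or phenyl, on this oxygen would also give a readable number in this assay. Also open, going by these compounds, is what a longer chain, such as octyl, would give there.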